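Benzyl-type amine variation on the chalcone core

The source may report more compounds than this note shows. Statements on the series, on what has been measured and on what is new or still open speak of the compounds shown alone.

Measured so far:
compound 1 `COc1cc(OC)c(C(=O)/C=C/c2ccccc2Cl)c(O)c1CN(C)CCCN(C)C` gives 30900 nM
compound 2 `CCN(CC)Cc1c(OC)cc(OC)c(C(=O)/C=C/c2ccccc2Cl)c1O` gives 6700 nM
compound 3 `COc1cc(OC)c(C(=O)/C=C/c2ccccc2Cl)c(O)c1CN1CCCCC1` gives 3100 nM

In a functional assay on Bel-7402 cells (Homo sapiens) for antiproliferative activity, with a stated time of 72 h (a lower number here means a stronger inhibitor, a higher number a weaker inhibitor), compound 3 holds the lowest of the three numbers, with compound 2 nearest and compound 1 furthest. The next step goes to compound 4 `COc1cc(OC)c(C(=O)/C=C/c2ccccc2Cl)c(O)c1CN(C)C`: dimethylamino in place of piperidin-1-yl on a saturated chain carbon bound to an aromatic carbon.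

Both earlier steps that touch this position bear on it. Among the compounds with values here, the step of a 2.2-fold lower number from compound 2 to compound 3 (0.33 log units; beyond the scatter) and the step of a 10-fold lower number from compound 1 to compound 3 (1.00 log units; beyond the scatter) show that the amine at the saturated chain carbon bound to an aromatic carbon moves the number modestly but beyond the scatter, the piperidin-1-yl giving the lowest value so far. Dimethylamino is the smallest amine in the set and has no measured counterpart, so a move back toward compound 2 is expected, with a 1.8-fold higher number from compound 3 to compound 4 (0.25 log units; within the scatter) as the expected step. Compound 4 is therefore estimated at 5500 nM, between 1800 nM and 17000 nM.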

Compound 4, half-maximal inhibitory concentration: 21800 nM
Compound 4: middle estimate off by 4.0-fold (0.60 log units), on the low side; the measured number lies above the stated range.
By their numbers in this assay, from the lowest: compound 3; then compound 2; then compounds 4 and 1 (each within the scatter of the next).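

In this assay, within the data shown here, the choice of amine on the saturated chain carbon bound to an aromatic carbon carries more weight than the earlier compounds showed, since dimethylamino gives a 7.0-fold higher number from compound 3 to compound 4 (0.85 log units; beyond the scatter) and also a 3.3-fold higher number from compound 2 to compound 4 (0.51 log units; beyond the scatter) in this series. The step of a 1.4-fold lower number from compound 1 to compound 4 (0.15 log units; within the scatter) shows that removing the 2-(dimethylamino)ethyl from the chain amine leaves the number unchanged within the scatter. Nothing here accounts for these steps.

Going by these compounds, whether the piperidin-1-yl value depends on the ring itself remains open. A pyrrolidin-1-yl or morpholin-4-yl group at the same place would test this, and the dipropylamino group would extend the open-chain amines.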